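The source may report more compounds than this note shows. Statements on the series, on what has been measured and on what is new or still open speak of the compounds shown alone.

Measured compounds:
compound 1, `Cc1ccc(NC(=O)Nc2cc(C)nc3ccccc23)cc1`: > 25000 nM
compound 2, `Cc1cc(NC(=O)Nc2cccc(OC(F)(F)F)c2)c2ccccc2n1`: 25000 nM

Two ureas built on the same core were measured in an ADME assay on BJ cells (Homo sapiens) for cytotoxicity, with a stated time of 72 h; a lower number here means that less compound is needed, a higher number that more compound is needed for the effect. For compound 1 the result in this assay is only a limit of the assay, > 25000 nM, and not a number. Within the data shown here, compound 1 therefore sits at the limit of > 25000 nM in this assay, at which 1 of the 2 values shown sits, so the study knows only that its value lies at or beyond that point. Compound 2 gives 25000 nM in this assay, a value that sits right at the same concentration, so nothing separates the two beyond the scatter of the method.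

The next compound, compound 3, `Cc1cc(NC(=O)Nc2ccc(Cl)cc2)c2ccccc2n1`, differs from compound 1 in one place: chloro in place of methyl on an aromatic carbon. Among the measured compounds shown here, no step between measured compounds is available, so the size of the change must be estimated. Given that compound 1 stands at the limit of > 25000 nM in this assay, at which 1 of the 2 values shown sits, no step beyond the scatter is expected from compound 1 to compound 3, and the value for compound 3 is expected to stay near the top of the range. The step from compound 1 to compound 3 is expected to be a number no higher from compound 1 to compound 3 (the limit leaves the size open). In this assay compound 3 is estimated at 25000 nM, between 12000 nM and 50000 nM.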

Compound 3, half-maximal effective concentration: > 25000 nM
Compound 3: a limit, no number (the forecaster's own chance of this, stated with the estimate: 60%); the middle value lies on the limit itself.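

In this assay compound 3 gives > 25000 nM, which is a limit of the assay and not a number. Compound 1 also stands at a limit, so no step between compound 1 and compound 3 can be read: the limit of > 25000 nM in this assay, at which 2 of the 3 values shown sit.

The compounds shown leave open how far chloro in place of methyl actually shifts the value.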